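This account rests on a few compounds, and the source may have more. Where it says the series, first, only, none or still open, it means among the compounds named here.

Series notes. Compound 1 `Nc1c2c(=O)[nH]c(-c3ccccc3)cc2nn1-c1ccccc1` and compound 2 `COc1ccc(-c2cc3nn(-c4ccccc4)c(N)c3c(=O)[nH]2)cc1` share one core and differ at a single aromatic carbon. In an assay on isolated protein for inhibition of protein kinase C zeta type (Homo sapiens), read by mobility shift assay, tested at 30 uM (a higher number here means more inhibition at the concentration tested (going by the name of the read-out), a lower number less inhibition), compound 1 gives -163%, and compound 2 gives 0%. Going by the values given here, the one step measured so far, a number 163 percentage points higher from compound 1 to compound 2 (beyond the scatter), is large. Compound 2 thus stands highest of the two numbers, with compound 1 the nearest to it and well apart.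

Compound 3 `CN1CCN(c2ccc(-c3cc4nn(-c5ccccc5)c(N)c4c(=O)[nH]3)cc2)CC1` is the next member. (4-methylpiperazin-1-yl in place of methoxy on an aromatic carbon). Among the compounds with values here, no measured step covers this change: the only step known alters the same aromatic carbon but with a different group entering, so it speaks to the place rather than to the group. With compound 2 at 0% as the only anchor, the expected step is a number 5 percentage points higher from compound 2 to compound 3 (within the scatter), none beyond the scatter. Compound 3 is therefore estimated at 5% in this assay, with a range from -40% to 40%.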

Compound 3, a percentage reported as inhibition, at one concentration (the size of the read-out at that concentration, not a potency): 23%
For compound 3 the middle estimate is 18 percentage points below the measured one, within the range that was stated.
By their numbers in this assay, from the lowest: compound 1; then compound 2; then compound 3.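

At the aromatic carbon para to a large group, 4-methylpiperazin-1-yl in place of methoxy gives a number 23 percentage points higher from compound 2 to compound 3 (beyond the scatter) in this assay, so the group entering this position, and not only the replacement of hydrogen, changes the read-out. Measured against hydrogen, the same group gives a number 186 percentage points higher from compound 1 to compound 3 (beyond the scatter), while methoxy gives a number 163 percentage points higher from compound 1 to compound 2 (beyond the scatter); most of the rise therefore appears with either group, and the choice between them adds a modest part. Nothing available accounts for the difference between these two groups.

The compounds shown leave open whether the gain from methoxy to 4-methylpiperazin-1-yl needs the ring, as a simple dimethylamino group or a morpholine at this carbon could show. A carboxylic acid at the same carbon would test whether the rise extends beyond these amine and ether groups.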